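From cyclopropyl to cyclopentyl on the amine chain

The compounds below may be only part of what the source reports. "The series", "measured", "known", "first", "only" and "open" are said of these compounds alone.

Measured so far in an ADME assay on Caco-2 cells (Homo sapiens) for permeability, read by LC-MS, with a stated time of 2 h (on this read-out higher numbers stand for higher permeability and lower numbers for lower permeability), for three compounds
compound 1 `CCN(Cc1ccc(OCCN2C(=O)CCC2=O)c(C)c1)C(CC(=O)O)c1ccc(Cl)cc1` gives 3.9 nm/s
compound 2 `Cc1cc(CN(CC2CC2)C(CC(=O)O)c2ccc(Cl)cc2)ccc1OCCN1C(=O)CCC1=O` gives 5.2 nm/s
compound 3 `Cc1cc(CN(CC2CC2)[C@@H](CC(=O)O)c2ccc(Cl)cc2)ccc1OCCN1C(=O)CCC1=O` gives 7.3 nm/s

As a 1.3-fold higher number from compound 1 to compound 2 (0.12 log units; within the scatter) and a 1.4-fold higher number from compound 2 to compound 3 (0.15 log units; within the scatter) show, compound 2 stands within the scatter of both other compounds.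

Compound 4 `Cc1cc(CN(CC2CCCC2)C(CC(=O)O)c2ccc(Cl)cc2)ccc1OCCN1C(=O)CCC1=O` is not yet measured. It carries cyclopentyl in place of cyclopropyl on a saturated chain carbon bound to an amine nitrogen. The change reads cyclopentyl in place of cyclopropyl on a saturated chain carbon bound to an amine nitrogen and the same difference, cut one bond further out, is cyclopropylmethyl to cyclopentylmethyl.

Among the compounds with values here, only one measured step touches this place. That step is a 1.3-fold higher number from compound 1 to compound 2 (0.12 log units; within the scatter) with cyclopropyl in place of methyl, and it stays within the scatter. The other step, a 1.4-fold higher number from compound 2 to compound 3 (0.15 log units; within the scatter) comes with the fact that one of compounds 2 and 3 is drawn with a defined configuration and the other without, at the place where they differ and leaves the group at this place unchanged, so it gives no guide here.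

Within the data shown here, one small step at this place is thin ground, but going by a 1.3-fold higher number from compound 1 to compound 2 (0.12 log units; within the scatter) as the only guide, no step beyond the scatter is expected. In this assay the step expected is a 1.1-fold higher number from compound 2 to compound 4 (0.02 log units; within the scatter) by this estimate. For compound 4 the estimated value is 5.5 nm/s with an expected range from 2.8 nm/s to 11 nm/s in the same read-out.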

Compound 4, apparent permeability: 28.9 nm/s
Compound 4: the middle estimate sits 5.3-fold (0.72 log units) below what was measured; the whole stated range lies below it.
By their numbers in this assay, from the lowest: compounds 1, 2 and 3 (each within the scatter of the next); then compound 4.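

In this assay, within the data shown here, the place on a saturated chain carbon bound to an amine nitrogen proves sensitive to the group it carries: cyclopentyl in place of cyclopropyl brings a 5.6-fold higher number from compound 2 to compound 4 (0.74 log units; beyond the scatter), the first step at this place to leave the scatter. Against methyl, cyclopentyl brings a 7.4-fold higher number from compound 1 to compound 4 (0.87 log units; beyond the scatter), while cyclopropyl in place of methyl stays at a 1.3-fold higher number from compound 1 to compound 2 (0.12 log units; within the scatter), so among these three groups only cyclopentyl separates from the other two. Nothing measured here bears on why this group at this place gives the higher number.

Open questions remain on how the step depends on the group: cyclobutyl and cyclohexyl would show whether it tracks ring size, and an open chain such as isopentyl would show whether a ring is needed at all. On these data alone, it also remains open whether the step carries over to a compound with cyclopentyl and the stereocentre at the saturated chain carbon drawn as S, the configuration drawn in compound 3.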